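Varying the substituent on the ring nitrogen of the shared core

The source may hold more compounds than are shown below. What is called first, only, known or untested is meant among the compounds shown, and "the series" means these compounds.

Going by the values given here, compound 2 `C/C(=C\C(=O)Nc1ccccc1OCCCC(=O)O)c1ccc2c(ccn2C(C(C)C)C(C)C)c1` gives 14 nM in an assay on Prostate gland for inhibition of steroid 5-alpha-reductase (Rattus norvegicus) (on this read-out lower numbers stand for stronger inhibition and higher numbers for weaker inhibition), the lower of the two numbers so far; compound 1 `CCCCn1ccc2cc(/C(C)=C/C(=O)Nc3ccccc3OCCCC(=O)O)ccc21` gives 43 nM. Among the compounds with values here, the one measured step, a 3.1-fold lower number from compound 1 to compound 2 (0.49 log units; beyond the scatter), was modest and concerned the same aromatic nitrogen. Compound 3 `CCCC(c1ccccc1)n1ccc2cc(/C(C)=C/C(=O)Nc3ccccc3OCCCC(=O)O)ccc21` carries 1-phenylbutyl in place of 1-isopropyl-2-methylpropyl on an aromatic nitrogen. Within the data shown here, no measured step covers an aromatic ring entering at this position, so the step is expected to be no larger than the one seen, in either direction. Compound 3 is therefore estimated at 15 nM (range 5 nM to 45 nM), a step of a 1.1-fold higher number from compound 2 to compound 3 (0.03 log units; within the scatter), not expected to lie beyond the scatter.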

Compound 3, half-maximal inhibitory concentration: 9.1 nM
Compound 3: middle estimate off by 1.6-fold (0.22 log units), on the high side; the measured number falls inside the stated range.
By their numbers in this assay, from the lowest: compounds 3 and 2 (each within the scatter of the next); then compound 1.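

In this assay, a six-membered aromatic ring of carbon only is accommodated on the aromatic nitrogen: 1-phenylbutyl in place of 1-isopropyl-2-methylpropyl gives a 1.5-fold lower number from compound 2 to compound 3 (0.19 log units; within the scatter) and leaves the two groups indistinguishable. Phenyl in place of hydrogen on the saturated chain carbon bound to the aromatic nitrogen gives a 4.7-fold lower number from compound 1 to compound 3 (0.67 log units; beyond the scatter) and so separates compound 3 from the butyl group of compound 1. No evidence accounts for either step.

Open, going by these compounds, is whether an amine or a carboxylic acid on the phenyl ring of 1-phenylbutyl would hold this level. Also open, on these data alone, is how a shorter chain in place of the butyl part would compare.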